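Replacing the vinyl group of compound 3

The source may hold more compounds than are shown below. What is called first, only, known or untested is meant among the compounds shown, and "the series" means these compounds.

compound 1 `C=CC(=O)Nc1cccc(Oc2nc(Nc3ccn(C)n3)nc3c2CSCC3)c1`: > 50000 nM (a limit of the assay)
compound 2 `C=CC(=O)Nc1cccc(Oc2nc(Nc3cccc(C#N)c3)nc3c2CSCC3)c1`: 21700 nM
compound 3 `C=CC(=O)Nc1cccc(Oc2nc(Nc3ccc(OC)cc3)nc3c2CSCC3)c1`: 11700 nM

In a functional assay on MCF7 cells (Homo sapiens) for antiproliferative activity, read by MTT assay, with a stated time of 72 h (a lower number here means a stronger inhibitor, a higher number a weaker inhibitor), compound 3 stands level with compound 2: a 1.9-fold lower number from compound 2 to compound 3 (0.27 log units; within the scatter). Compound 1 gives only a limit and no number.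

Compound 4 `COc1ccc(Nc2nc3c(c(Oc4cccc(NC(=O)/C=C/C(C)C)c4)n2)CSCC3)cc1` keeps the 4-methoxyphenyl of compound 3 and carries one change: 3-methylbut-1-en-1-yl in place of vinyl on a carbonyl carbon. Among the measured compounds shown here, no measured step touches this place. For the measured compounds named here, the nearest guides are an at least 2.3-fold lower number from compound 1 to compound 2 (0.36 log units; beyond the scatter) and an at least 4.2-fold lower number from compound 1 to compound 3 (0.63 log units; beyond the scatter), both made on the nitrogen, and they show only that one change can move this series beyond the scatter. Going by the values given here, a modest move toward a higher number is expected, though no measured step supports that direction. The estimated step is a 2.1-fold higher number from compound 3 to compound 4 (0.33 log units; beyond the scatter). Compound 4 is expected at 25000 nM, within an estimated range of 9000 nM to 50000 nM.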

Compound 4, half-maximal inhibitory concentration: > 50000 nM
Compound 4: a limit, no number; the forecaster's own chance of this, stated with the estimate: 25%; middle value at least 2.0-fold (0.30 log units) from the limit.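

Among the compounds shown here, the carbonyl-carbon position, untouched by the earlier steps, also moves the series beyond the scatter: in this assay, 3-methylbut-1-en-1-yl in place of vinyl gives an at least 4.2-fold higher number from compound 3 to compound 4 (0.63 log units; beyond the scatter). With the 4-methoxyphenyl kept, vinyl is the better of these two groups at this position. Compound 4 gives a limit and not a number, so the full size of this step stays unknown: the limit of > 50000 nM in this assay, at which 2 of the 4 values shown sit.

Open, from the compounds shown here alone, is how an ethyl group in place of vinyl, or a vinyl carrying a dimethylamine, would read in this assay. Also open, going by these compounds, is whether the same change carries over to the 3-cyanophenyl of compound 2.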